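Chloro for hydrogen on a phenyl, two cores compared

A few compounds are considered here, and "the series" means these few. Any claim that something is new, unique, unknown or untested is made for them only; others in the source may bear on it.

Measured compounds:
compound 1 `COc1ccc(C2CC(c3ccccc3)=NN2c2nc(-c3ccccc3)c(C#N)c(=O)n2C)cc1` — 12800 nM
compound 2 `COc1ccc(C2CC(c3ccc(Cl)cc3)=NN2c2nc(-c3ccccc3)c(C#N)c(=O)n2C)cc1` — 11100 nM
compound 3 `Cn1c(N2N=C(c3ccccc3)CC2c2ccccc2)nc(-c2ccc(Cl)cc2)c(C#N)c1=O` — 29100 nM

All three numbers come from a functional assay on MDA-MB-231 cells (Homo sapiens) for antiproliferative activity, with a stated time of 72 h; on this read-out higher numbers stand for weaker inhibition and lower numbers for stronger inhibition. Compound 2 differs from compound 1 by chloro in place of hydrogen on an aromatic carbon, and this gives a 1.2-fold lower number from compound 1 to compound 2 (0.06 log units; within the scatter). Compound 3 carries a different core; the difference between the two cores is not broken down here, and the two values simply show compound 3 at the higher number of the pair with compound 1.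

Compound 4 `Cn1c(N2N=C(c3ccccc3)CC2c2ccc(Cl)cc2)nc(-c2ccc(Cl)cc2)c(C#N)c1=O` differs from compound 3 by chloro in place of hydrogen on an aromatic carbon. Among the compounds with values here, this is the same change as the one from compound 1 to compound 2, made on the other core. Because a 1.2-fold lower number from compound 1 to compound 2 (0.06 log units; within the scatter) stayed within the scatter, a step of about a 1.2-fold lower number from compound 3 to compound 4 (0.07 log units; within the scatter) is expected in this assay. For compound 4 a value of 25000 nM is estimated, expected to fall between 12000 nM and 52000 nM.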

Compound 4, half-maximal inhibitory concentration: 25100 nM
Estimate against measurement, compound 4: 1.0-fold (0.00 log units) below; measured number inside the range.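

In this assay, phenyl to 4-chlorophenyl on the core of compound 3 gives a 1.2-fold lower number from compound 3 to compound 4 (0.06 log units; within the scatter). Set beside the earlier step, the change behaves alike on the two cores: the same change on two cores in this assay, a 1.2-fold lower number (0.06 log units; within the scatter) from compound 1 to compound 2 and a 1.2-fold lower number (0.06 log units; within the scatter) from compound 3 to compound 4, 1.0-fold (0.00 log units) apart, within the scatter of two such steps. This shows that the change carries across these two cores as a step within the scatter on each, but it does not show a real gain in inhibition on either core, and two pairs establish no rule for other cores in the series.

From the compounds shown here alone, whether an amine, a carboxylic acid or a longer chain in place of the chloro would give a step beyond the scatter remains open. Also open, going by these compounds, is whether the same flat result would hold with the chloro elsewhere on that ring.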